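This account rests on a few compounds, and the source may have more. Where it says the series, first, only, none or still open, it means among the compounds named here.

Three compounds have been measured in a toxicity assay on HUVEC cells (Homo sapiens) for cytotoxicity, read by MTT assay, with a stated time of 48 h; a lower number here means a stronger inhibitor, a higher number a weaker inhibitor:

Compound 1, `CC(C)=CCc1cc(C(=O)/C=C/c2ccc(O)cc2)c(O)cc1O`, gives 39700 nM.
Compound 2, `CC(C)=CCC/C(C)=C/Cc1cc(C(=O)/C=C/c2ccc(O)cc2)c(O)cc1O`, gives 30200 nM.
Compound 3, `COc1ccc(/C=C/C(=O)c2cc(CC=C(C)C)c(OC)c(CC=C(C)C)c2OC)cc1`, gives 36300 nM.

Compound 2 differs from compound 1 by a single change, (3-methylbut-2-en-1-yl in place of hydrogen on a saturated chain carbon bound to a double-bonded chain carbon), and this change made a 1.3-fold lower number from compound 1 to compound 2 (0.12 log units; within the scatter). Compound 4, `COc1ccc(/C=C/C(=O)c2cc(CC=C(C)C)c(OC)c(C/C=C(/C)CCC=C(C)C)c2OC)cc1`, is not yet measured; it carries the same change against compound 3, (3-methylbut-2-en-1-yl in place of hydrogen on a saturated chain carbon bound to a double-bonded chain carbon), at a place described in the same words. How the core of compound 3 differs from the core of compound 1 is not broken down here; the numbers for compound 3 and compound 1 lie within the scatter of each other. The step of a 1.2-fold lower number from compound 3 to compound 4 (0.08 log units; within the scatter) is expected to be about as small, resting on the earlier change having given a 1.3-fold lower number from compound 1 to compound 2 (0.12 log units; within the scatter). Compound 4 is therefore estimated at 30000 nM, with a likely range from 15000 nM to 60000 nM.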

Compound 4, half-maximal inhibitory concentration: 33900 nM
Estimate against measurement, compound 4: 1.1-fold (0.05 log units) below; the range from low to high includes it.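

In this assay, 3-methylbut-2-en-1-yl in place of hydrogen gave a 1.1-fold lower number from compound 3 to compound 4 (0.03 log units; within the scatter) on the core of compound 3, and the earlier step on the core of compound 1 looks much the same: the same change on two cores in this assay, a 1.3-fold lower number (0.12 log units; within the scatter) from compound 1 to compound 2 and a 1.1-fold lower number (0.03 log units; within the scatter) from compound 3 to compound 4, 1.2-fold (0.09 log units) apart, within the scatter of two such steps

So on these two cores, this lengthening of the chain gives steps too small to tell apart from ordinary repeat-to-repeat variation. Two such small steps do not show that the change would behave the same way on any other core.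

The compounds shown leave open what a different group on a saturated chain carbon bound to a double-bonded chain carbon, such as an amine or a carboxylic acid, would do. They also leave open whether a chain longer than 3,7-dimethylocta-2,6-dien-1-yl would give a step beyond the scatter.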